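The source may report more compounds than this note shows. Statements on the series, on what has been measured and on what is new or still open speak of the compounds shown alone.

Working notes on a short series built on the shared core of compound 1, `Cc1cn2cccc(OCc3ccccc3)c2n1`. In a functional assay on the whole organism (stomach) for inhibition, with Canis familiaris (Canis lupus familiaris) as the target, at a dose of 5 mg/kg by the intravenous route (on this read-out higher numbers stand for a stronger effect at the one dose given and lower numbers for a weaker effect), compound 1 gives 70%. Compound 2, `Cc1nc2c(OCc3ccccc3)cccn2c1C[S+](C)[O-]`, gives 18%. Compound 3, `COC(=O)Cc1c(C)nc2c(OCc3ccccc3)cccn12`, gives 16%. Compound 3 holds the lowest of the three numbers, although its gap to compound 2 lies within the scatter, while the gap to compound 1 is wide: a number 54 percentage points lower from compound 1 to compound 3 (beyond the scatter). Both substituted compounds fall together, as a number 52 percentage points lower from compound 1 to compound 2 (beyond the scatter) and then a number 2 percentage points lower from compound 2 to compound 3 (within the scatter) show; replacing the group on the chain carbon leaves the read-out essentially unchanged.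

Compound 4, `CC(=O)OCc1c(C)nc2c(OCc3ccccc3)cccn12`, is the next member. It differs from compound 3 only by acetoxy in place of methoxycarbonyl on a saturated chain carbon bound to an aromatic carbon. Going by the values given here, the one step that bears on it is the exchange at the same place between compound 2 and compound 3, which was small and within the scatter. Among the compounds with values here, nothing among the measured compounds suggests that trading one four-heavy-atom group for another at that carbon would recover the level of compound 1. A step of a number 1 percentage points higher from compound 3 to compound 4 (within the scatter) is therefore expected, well within the scatter. For compound 4 the estimated inhibition is 17%, with a range from 5% to 35%.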

Compound 4, a percentage reported as inhibition, in the whole organism at one dose (the size of the read-out at that dose, not a potency): 87%
For compound 4 the middle estimate is 70 percentage points below the measured one, outside the stated range (above it).
By their numbers in this assay, from the lowest: compounds 3 and 2 (each within the scatter of the next); then compound 1; then compound 4.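

At the saturated chain carbon bound to an aromatic carbon, the read-out depends on how the group is joined and not only on what it is made of: acetoxy and methoxycarbonyl have the same atoms and the same counts, yet in this assay the exchange gives a number 71 percentage points higher from compound 3 to compound 4 (beyond the scatter), and replacing the group of compound 2 gives a number 69 percentage points higher from compound 2 to compound 4 (beyond the scatter), where the earlier exchange at this carbon gave only a number 2 percentage points lower from compound 2 to compound 3 (within the scatter). Substitution on the aromatic carbon of the shared core therefore does not lower the read-out in every case, since acetoxymethyl in place of hydrogen gives a number 17 percentage points higher from compound 1 to compound 4 (beyond the scatter); compound 2 and compound 3 stand against any general claim of a rise with substitution, so the effect here belongs to acetoxymethyl alone. Nothing available accounts for this reversal between two groups of identical composition.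

Open, on these data alone, is whether the high read-out is specific to acetoxy or extends to hydroxy, an acetamido group or a longer acyl chain such as propionyloxy on the same carbon. With a single dose in this read-out, the series also gives no potency for compound 4 and leaves open how its effect would change at other doses.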